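Bromine removal on a fused aromatic ring and cytotoxicity

A few compounds are considered here, and "the series" means these few. Any claim that something is new, unique, unknown or untested is made for them only; others in the source may bear on it.

Of the compounds shown here, three from one series have so far been tested in an ADME assay on HepG2 cells (Homo sapiens) for cytotoxicity, read by CellTiter-Glo, with a stated time of 48 h; a lower number here means that less compound is tolerated, a higher number that more compound is tolerated. Compound 1 `CS(=O)(=O)c1ccc(-c2nc3ccc(Br)cc3nc2-c2ccc(Cl)cc2)cc1` gives 2000 nM in this assay. Compound 2 `CCCCNc1nc2ccccc2nc1S(C)(=O)=O` gives 12600 nM in this assay. Compound 3 `CCCCNc1nc2cc(Br)ccc2nc1S(C)(=O)=O` gives 7940 nM in this assay. Compound 1 thus sits lowest of the three, and its gaps to compound 3 and to compound 2 are both beyond the scatter.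

Compound 3 and compound 2 differ in one place only: hydrogen in place of bromo on an aromatic carbon. This change made a 1.6-fold higher number from compound 3 to compound 2 (0.20 log units; within the scatter).

Compound 4 `CS(=O)(=O)c1ccc(-c2nc3ccccc3nc2-c2ccc(Cl)cc2)cc1` has not yet been measured in this assay. It is related to compound 1 by hydrogen in place of bromo on an aromatic carbon. Among the measured compounds shown here, the difference between the core of compound 1 and the core of compound 3 is not broken down here; the two place descriptions are nonetheless the same word for word, so the step from compound 1 to compound 4 is the same change as the one from compound 3 to compound 2.

On that basis the step from compound 1 to compound 4 in this assay is expected to be of the same kind as the earlier one, a modest rise that stays within the scatter, because the measured step was a 1.6-fold higher number from compound 3 to compound 2 (0.20 log units; within the scatter). The expected step is a 1.5-fold higher number from compound 1 to compound 4 (0.18 log units; within the scatter). Compound 4 is therefore estimated at 3000 nM in this assay, with a likely range from 1500 nM to 6300 nM.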

Compound 4, half-maximal cytotoxic concentration: 10000 nM
Estimate against measurement, compound 4: 3.3-fold (0.52 log units) below, and the stated range ends below it.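

In this assay, hydrogen in place of bromo on an aromatic carbon gave a 5.0-fold higher number from compound 1 to compound 4 (0.70 log units; beyond the scatter), so on the core of compound 1 this single change has a clear effect on the number. The same change did not keep its size when carried from one core to the other: the same change on two cores in this assay, a 1.6-fold higher number (0.20 log units; within the scatter) from compound 3 to compound 2 and a 5.0-fold higher number (0.70 log units; beyond the scatter) from compound 1 to compound 4, 3.2-fold (0.50 log units) apart, beyond the scatter of two such steps. Among the compounds shown here, in this series, then, a step measured on one core was not a reliable guide to the size of the step on the other, but with only two pairs this does not show which difference between the cores goes with the larger step, or how the core and the change work together.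

The compounds shown leave open whether the same change on a third core would fall closer to the smaller step or the larger one, or outside both. They also leave open how a fluoro or a methoxy group on that aromatic carbon would read in this assay on either core, as only bromo and hydrogen appear there.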